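Thiazole acetic acids: aryl swap at the ring carbon

A few compounds are considered here, and "the series" means these few. Any claim that something is new, unique, unknown or untested is made for them only; others in the source may bear on it.

Measured so far:
compound 1 `COc1ccc(C(c2ccccc2)c2nc(-c3ccc(Cl)cc3)c(CC(=O)O)s2)cc1` — 8.4 nM
compound 2 `O=C(O)Cc1sc(C(c2ccccc2)c2ccccc2)nc1-c1ccccc1` — 570 nM
compound 3 `O=C(O)Cc1sc(C(c2ccc(F)cc2)c2ccc(F)cc2)nc1-c1cccc(F)c1` — 1.4 nM

In an in vitro assay on HEK385-7 cells for displacement of a labelled ligand from prostaglandin D2 receptor 2 (Homo sapiens) (on this read-out lower numbers stand for stronger inhibition and higher numbers for weaker inhibition), compound 3 gives the lowest number of the three; compound 1 gives the nearest number and compound 2 the furthest, both gaps beyond the scatter. Going by the values given here, no two measured compounds differ in one place only, so no single step is known.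

Compound 4 `CN(C)c1cc(-c2nc(C(c3ccc(F)cc3)c3ccc(F)cc3)sc2CC(=O)O)ccn1` is not yet measured. It differs from compound 3 in one place: 2-(dimethylamino)pyridin-4-yl in place of 3-fluorophenyl on an aromatic carbon.

Among the compounds with values here, the set holds no precedent for a ring with a hetero atom at this place, so a direction cannot be read from it. A modest step from compound 3 to compound 4 toward a higher number in this assay is expected, a 3.6-fold higher number from compound 3 to compound 4 (0.55 log units; beyond the scatter), without confidence. Compound 4 is estimated at 5 nM, within 1 nM to 30 nM.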

Compound 4, half-maximal inhibitory concentration: 380 nM
Estimate against measurement, compound 4: 76-fold (1.88 log units) below; measured number outside the range, above it.
By their numbers in this assay, from the lowest: compound 3; then compound 1; then compounds 4 and 2 (each within the scatter of the next).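

In this assay, going by these compounds alone, the aryl group on the aromatic carbon next to the ring nitrogen proves sensitive: 2-(dimethylamino)pyridin-4-yl in place of 3-fluorophenyl gives a 270-fold higher number from compound 3 to compound 4 (2.43 log units; beyond the scatter) as the first single-place step. The change is large, so this position does not accept every aromatic ring. No supporting data bear on the cause of this loss.
Still open, from the compounds shown here alone, is whether the ring nitrogen or the dimethylamino group accounts for the step. Plain pyridin-4-yl and 3-(dimethylamino)phenyl at this position would separate the two.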